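A few compounds are considered here, and "the series" means these few. Any claim that something is new, unique, unknown or untested is made for them only; others in the source may bear on it.

Within the data shown here, in an ADME assay on microsomes from liver (Rattus norvegicus) for metabolic stability (a lower number here means that the compound disappears faster, a higher number that the compound lasts longer), compound 2 `CC#C[C@@H](Cc1nnn[nH]1)c1ccc(OCc2ccc3scc(-c4ccc(OCCOC)cc4C)c3c2)cc1` gives 0.217 h and stands alongside compound 1 `CC#C[C@@H](Cc1nnn[nH]1)c1ccc(OCc2ccc3scc(-c4ccccc4C(F)(F)F)c3c2)cc1`, which gives 0.167 h; the only step recorded, a 1.3-fold higher number from compound 1 to compound 2 (0.11 log units; within the scatter), lies within the scatter, so the two numbers cannot be ranked. Compound 3 `CC#C[C@@H](Cc1nnn[nH]1)c1ccc(OCc2ccc3sc(F)c(-c4ccc(OCCOC)cc4C)c3c2)cc1` differs from compound 2 by fluoro in place of hydrogen on an aromatic carbon. Among the measured compounds shown here, no measured step concerns this kind of change: the single step available swaps one aromatic substituent of the shared core for another and does not move beyond the scatter, so it gives neither a direction nor a size for a fluoro in place of hydrogen on an aromatic carbon of a five-membered aromatic ring with 1 sulfur. With nothing more to go on, the expected step of a 1.2-fold higher number from compound 2 to compound 3 (0.06 log units; within the scatter) is set near zero, with no move beyond the scatter. Compound 3 is accordingly estimated at 0.25 h in this assay, within a range from 0.12 h to 0.5 h.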

Compound 3, half-life: 0.35 h
Compound 3: the middle estimate sits 1.4-fold (0.15 log units) below what was measured; the measured number falls inside the stated range.
By their numbers in this assay, from the lowest: compounds 1, 2 and 3 (each within the scatter of the next, the first and the last beyond it).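

In this assay, fluoro in place of hydrogen on an aromatic carbon of the five-membered aromatic ring with 1 sulfur, next to the ring sulfur and next to the ring atom that bears a 4-(2-methoxyethoxy)-2-methylphenyl group, gives a 1.6-fold higher number from compound 2 to compound 3 (0.21 log units; within the scatter). Among these compounds, this is the first measured step at this position, and it shows that here the fluoro leaves the half-life of compound 3 unranked against that of compound 2. Nothing measured bears on the origin of this result.

On these data alone, whether a chloro or a nitrile on the same carbon would also stay within the scatter remains open. Also open, as far as these compounds go, is whether the fluoro step would read the same with the 2-(trifluoromethyl)phenyl group of compound 1 on the neighbouring ring atom.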